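Working notes: inverted ring configuration in a tetrahydropyran series

A few compounds are considered here, and "the series" means these few. Any claim that something is new, unique, unknown or untested is made for them only; others in the source may bear on it.

Three congeners of the shared core have been measured in a functional assay on HeLa cells (Homo sapiens) for cytotoxicity, read by WST assay, with a stated time of 48 h; a higher number here means a weaker inhibitor, a lower number a stronger inhibitor. Compound 1 `COc1cccc([C@H](O)[C@H]2CO[C@H](c3ccc(OC)c(OC)c3)[C@@H](C/C=C/c3ccc(OC)c(OC)c3)C2)c1` gives 21200 nM, which is the second highest of the three numbers. Compound 2 `COc1ccc(/C=C/C[C@H]2C[C@@H]([C@@H](O)c3ccccc3)CO[C@@H]2c2ccc(OC)c(OC)c2)cc1OC` gives 15500 nM, and compound 3 `COc1ccc(/C=C/C[C@H]2C[C@@H]([C@@H](O)c3ccc(OC)c(OC)c3)CO[C@@H]2c2ccc(OC)c(OC)c2)cc1OC` gives 23800 nM. The three measured steps are all small: a 1.4-fold lower number from compound 1 to compound 2 (0.14 log units; within the scatter), a 1.1-fold higher number from compound 1 to compound 3 (0.05 log units; within the scatter) and a 1.5-fold higher number from compound 2 to compound 3 (0.19 log units; within the scatter). None of them moves the number beyond the scatter, so the aromatic substitution pattern on the carbinol aryl group appears not to matter within this set.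

Compound 4 `COc1cccc([C@H](O)[C@H]2CO[C@@H](c3ccc(OC)c(OC)c3)[C@H](C/C=C/c3ccc(OC)c(OC)c3)C2)c1` is the next candidate. Relative to compound 1 it shows (the two compounds have the same atoms and bonds and differ only in configuration as drawn: 2 of 5 stereo elements differ; a stereocentre at a saturated ring carbon is drawn S in compound 1 and R in compound 4; a stereocentre at a saturated ring carbon is drawn S in compound 1 and R in compound 4). Among the measured compounds shown here, no measured pair in the set probes a change of configuration, so the effect of this change cannot be read from any existing step; the only guidance is that every change tried so far has left the number within the scatter, and the three values sit close together. A flat response is therefore the working expectation, with no direction favoured.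

For compound 4 the estimated value in this assay is 20000 nM, with a range from 7000 nM to 60000 nM. The expected step is a 1.1-fold lower number from compound 1 to compound 4 (0.03 log units; within the scatter), essentially no change beyond the scatter, though the range is kept wide to allow for an untested kind of change.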

Compound 4, half-maximal inhibitory concentration: 18600 nM
Compound 4: the middle estimate sits 1.1-fold (0.03 log units) above what was measured; the range from low to high includes it.
By their numbers in this assay, from the lowest: compounds 2, 4, 1 and 3 (each within the scatter of the next).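

Inverting two of the five stereo elements, both stereocentres at saturated ring carbons, is the first change of configuration seen in the series, and in this assay it gives a 1.1-fold lower number from compound 1 to compound 4 (0.06 log units; within the scatter). The response to configuration at these two ring carbons is therefore as flat as the response to the aromatic substitution changes among compound 1, compound 2 and compound 3, so this paired inversion does not separate compound 1 from compound 4. The step reads as a purely stereochemical comparison, with no substituent change mixed in: the fact that compounds 1 and 4 differ only in the configuration as drawn.

The compounds shown leave open what each of the two stereocentres does on its own, since they change together here, and what the carbinol stereocentre contributes. They also leave open whether any change moves the number beyond the scatter, for instance an amine or a carboxylic acid on the carbinol aryl group in place of the methoxy groups, or a longer chain in place of the one carrying the second 3,4-dimethoxyphenyl group.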